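The source may hold more compounds than are shown below. What is called first, only, known or untested is meant among the compounds shown, and "the series" means these compounds.

Measured compounds, activity in a functional assay on HL-60 cells (Homo sapiens) for antiproliferative activity, read by MTT assay, with a stated time of 24 h; on this read-out lower numbers stand for stronger inhibition and higher numbers for weaker inhibition:

compound 1, `CCCCc1oc2ccccc2c1C(=O)c1ccc(OCC(=O)N2CCN(C(=O)OC(C)(C)C)CC2)cc1`: > 50000 nM
compound 2, `CCCCc1oc2ccccc2c1C(=O)c1ccc(OCC(=O)Nc2ccccc2)cc1`: > 50000 nM

Compound 1 gives only a limit of the assay, > 50000 nM, and no number. Compound 2 likewise gives only a limit, > 50000 nM, not a number. Among the measured compounds shown here, compound 2 therefore stands nowhere on a scale: both values shown sit at the same limit, (the limit of > 50000 nM in this assay, at which 2 of the 2 values shown sit), so no step between measured compounds is known and no size of change has been seen at all.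

Compound 3, `CCCCc1oc2ccccc2c1C(=O)c1ccc(OCCCC(=O)N2CCCCC2)cc1`, has not been measured in this assay. It differs from compound 2 as follows: 2-((piperidin-1-yl)carbonyl)ethyl in place of phenylcarbamoyl on a saturated chain carbon bound to an oxygen on an aromatic ring.

With both measured compounds sitting at the limit, there is no measured step to set the size of an expectation for this change, and nothing shown points to a number within the assay's range. The step from compound 2 to compound 3 is expected to be none beyond the scatter, a step that the limit leaves unreadable from compound 2 to compound 3, with compound 3 expected to give again a limit rather than a number. Compound 3 is estimated at 60000 nM in this assay, expected between 15000 nM and 200000 nM.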

Compound 3, half-maximal inhibitory concentration: 31900 nM
For compound 3 the middle estimate is 1.9-fold (0.27 log units) above the measured one; low and high end bracket the measured number.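

In this assay compound 3 is the only compound shown that gives a number rather than a limit, so a read-out inside the range of the assay is possible with a change at this place, on a saturated chain carbon bound to an oxygen on an aromatic ring. Putting 2-((piperidin-1-yl)carbonyl)ethyl in place of phenylcarbamoyl gives an at least 1.5-fold lower number from compound 2 to compound 3 (0.19 log units; that floor lies within the scatter), so only a floor for the step is known and its true size stays unread. The change replaces the aromatic ring with a non-aromatic one, removes the amide hydrogen and lengthens the chain all at once, and the values cannot separate these differences, while most of the series still stands at one limit: the limit of > 50000 nM in this assay, at which 2 of the 3 values shown sit.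

The compounds shown leave open whether the longer chain or the piperidinyl carbonyl end matters, since neither phenylcarbamoyl on 3-carbon-longer chains nor the piperidinyl carbonyl on the shorter chain appears among them. Also open, on these data alone, is how other chain ends, such as a morpholine amide or a carboxylic acid, would read in this assay.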